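Adding a Third Methoxy Group: Expected Effect for Compound 3

The source may report more compounds than this note shows. Statements on the series, on what has been measured and on what is new or still open speak of the compounds shown alone.

Measured compounds:
compound 1, `COc1ccc(C(=O)/C=C/c2cc(-c3cc(OC)c(OC)c(OC)c3)n[nH]2)cc1OC`: -88%
compound 2, `COc1ccc(C(=O)/C=C/c2cc(-c3cc(OC)c(OC)c(OC)c3)n[nH]2)cc1`: -37%

In a functional assay on SF-268 cells (Homo sapiens) for cytotoxicity, read by sulforhodamine B assay, with a stated time of 48 h, tested at 100 uM (on this read-out lower numbers stand for a stronger effect and higher numbers for a weaker effect at the one concentration tested), compound 1 gives -88%, the lowest of the two numbers recorded. Compound 2 gives -37%. Among the compounds with values here, the one measured step is a number 51 percentage points higher from compound 1 to compound 2 (beyond the scatter), where a hydrogen stands in place of a methoxy group on an aromatic carbon, so taking a methoxy group away weakened the effect considerably.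

Compound 3, `COc1cc(C(=O)/C=C/c2cc(-c3cc(OC)c(OC)c(OC)c3)n[nH]2)cc(OC)c1OC`, differs from compound 1 by methoxy in place of hydrogen on an aromatic carbon. This is the reverse kind of change: a methoxy group is added rather than removed, at a place where compound 1 already carries two. The measured step only shows that losing a methoxy group hurts; it does not show that gaining a further one helps, and compound 1 is already near the floor of this read-out. Compound 3 is therefore expected to land close to compound 1, with a number 3 percentage points higher from compound 1 to compound 3 (within the scatter) estimated to stay within the scatter, giving an expected value of -85% in the range -100% to -60%.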

Compound 3, a percentage reported as activity, at one concentration (the size of the read-out at that concentration, not a potency): -75%
Estimate against measurement, compound 3: 10 percentage points below; measured number inside the range.
By their numbers in this assay, from the lowest: compound 1; then compound 3; then compound 2.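

In this assay there is a number 13 percentage points higher from compound 1 to compound 3 (beyond the scatter) when methoxy takes the place of hydrogen ortho to a methoxy group and meta to a large group. Read with a number 51 percentage points higher from compound 1 to compound 2 (beyond the scatter) where a methoxy group is lost, this shows that on this ring both taking away and adding a methoxy group weaken the effect, with the addition costing less, so more methoxy groups do not simply mean a stronger effect. No measurement available here gives a reason for this result.

From the compounds shown here alone, what remains open is whether this place tolerates only hydrogen or would accept another group, such as a hydroxyl, a fluorine or an amine. Going by these compounds, it is also open whether a longer chain, such as ethoxy, in place of the added methoxy would change the effect further.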